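The source may hold more compounds than are shown below. What is called first, only, known or untested is meant among the compounds shown, and "the series" means these compounds.

Compound 1 `CC/C(=C(/c1ccc(/C=C/C(=O)O)cc1)c1cc2ccccc2[nH]1)c1ccc(C(F)(F)F)cc1` is one of three compounds that share a core and differ only in the aromatic ring attached to it. In a functional assay on MCF7 cells (Homo sapiens) for inhibition (a higher number here means a weaker inhibitor, a lower number a stronger inhibitor), compound 1 gives 139 nM, the second highest of the three numbers. Compound 2 `CC/C(=C(/c1ccc(/C=C/C(=O)O)cc1)c1cc2ccccc2[nH]1)c1cccc(Cl)c1Cl` carries a 2,3-dichlorophenyl group and gives 898 nM; compound 3 `CC/C(=C(/c1ccc(/C=C/C(=O)O)cc1)c1cc2ccccc2[nH]1)c1cccc(F)c1C#N` carries a 2-cyano-3-fluorophenyl group and gives 40 nM. The step of a 6.5-fold higher number from compound 1 to compound 2 (0.81 log units; beyond the scatter) and the step of a 3.5-fold lower number from compound 1 to compound 3 (0.54 log units; beyond the scatter) show that swapping this ring can move the number in either direction, and the step of a 22-fold lower number from compound 2 to compound 3 (1.35 log units; beyond the scatter) shows how wide that range is.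

Compound 4 `CC/C(=C(/c1ccc(/C=C/C(=O)O)cc1)c1cc2ccccc2[nH]1)c1ccc(Cl)c(C)c1` differs from compound 1 by 4-chloro-3-methylphenyl in place of 4-(trifluoromethyl)phenyl on a double-bonded chain carbon bound to a double-bonded chain carbon and a saturated chain carbon. For the measured compounds named here, none of the measured steps makes this exact change: a single substituent at the 4-position is kept as in compound 1, while a methyl is added. Going by the values given here, since compound 1 gives 139 nM and no step here tells what a chloro or methyl contributes, only a modest shift is expected, and its direction is uncertain. Compound 4 is therefore estimated at 200 nM, between 70 nM and 600 nM, which means an expected step of a 1.4-fold higher number from compound 1 to compound 4 (0.16 log units; within the scatter).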

Compound 4, half-maximal inhibitory concentration: 840 nM
The estimate for compound 4 lay 4.2-fold (0.62 log units) below the measured number; the whole stated range lies below it.
By their numbers in this assay, from the lowest: compound 3; then compound 1; then compounds 4 and 2 (each within the scatter of the next).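

The new ring does not keep the potency of compound 1: a 6.0-fold higher number from compound 1 to compound 4 (0.78 log units; beyond the scatter) is a clear loss in this assay, even though the 4-chloro-3-methylphenyl group differs from 4-(trifluoromethyl)phenyl only in its substituents. It also places compound 4 level with the 2,3-dichlorophenyl compound, as a 1.1-fold lower number from compound 2 to compound 4 (0.03 log units; within the scatter) stays within the scatter, while a 21-fold higher number from compound 3 to compound 4 (1.32 log units; beyond the scatter) leaves a wide gap to the best ring so far. Among these four compounds, the two rings carrying chlorine give the two highest numbers, with no exception, but no measurement here explains this link.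

The compounds shown leave open whether the chlorine, the methyl or the pair accounts for the loss. A ring carrying only one of them would separate these, and a ring carrying an amine would test a quite different kind of group at this position.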